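Two Hydrazones Measured, a Carboxy Analogue Awaited

A few compounds are considered here, and "the series" means these few. Any claim that something is new, unique, unknown or untested is made for them only; others in the source may bear on it.

The study concerns a small set of hydrazones built on one shared core. Compound 1, `Cc1c(C(=O)N/N=C/c2ccc(N(C)C)cc2)no[n+]1[O-]`, carries a dimethylamino group on its aromatic ring. In a functional assay on the whole organism (strain albino) for inhibition, with Rattus norvegicus as the target, read by paw edema, with stated times of 1 h and 3 h, at a dose of 100 umol/kg by the oral route (on this read-out lower numbers stand for less inhibition and higher numbers for more inhibition at the one dose given (going by the name of the read-out)), compound 1 gives 19%. Compound 2, `Cc1c(C(=O)N/N=C/c2cccs2)no[n+]1[O-]`, differs in the aromatic part attached to the hydrazone, and in this assay compound 2 gives 0%. Of the two numbers compound 1 stands highest, and the gap down to compound 2 lies beyond the usual scatter.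

Compound 3, `Cc1c(C(=O)N/N=C/c2ccc(C(=O)O)cc2)no[n+]1[O-]`, has not yet been measured in this assay. It differs from compound 1 by carboxy in place of dimethylamino on an aromatic carbon. For the measured compounds named here, no step between two measured compounds covers this change, so any expectation rests only on the modest numbers of compounds 1 and 2. Both lie low, and compound 3 is expected to remain in that low region, with a step from compound 1 of about a number 9 percentage points lower from compound 1 to compound 3 (within the scatter), which would be a small downward move within the scatter or no move at all. Compound 3 is therefore estimated to give 10%, in a range from 0% to 28%.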

Compound 3, a percentage reported as inhibition, in the whole organism at one dose (the size of the read-out at that dose, not a potency): 16%
For compound 3 the middle estimate is 6 percentage points below the measured one; the measured number falls inside the stated range.
By their numbers in this assay, from the lowest: compound 2; then compounds 3 and 1 (each within the scatter of the next).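

In this assay, for the compounds shown here, the change to carboxy in place of dimethylamino on an aromatic carbon, para to a large group, gives a number 3 percentage points lower from compound 1 to compound 3 (within the scatter) and is the first step that can be read at this position. It shows that at this place a group with one hydrogen-bond donor and a double bond outside aromatic rings can stand in for a group with no hydrogen-bond donor, at the same count of heavy atoms, without the read-out moving beyond the scatter. Nothing available explains this result, and no property can be tied to either group.

From the compounds shown here alone, whether the same place would give a similar reading with a primary amine, a hydroxy group, an ethyl ester or a longer chain remains open, as does the reading with plain hydrogen there. Going by these compounds, the numbers also come from a single oral dose and are sizes of effect rather than potencies, so it remains open whether compound 1 and compound 3 would stay this close at other doses.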